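Phenyl substitution in the series: compound 3 to compound 4

The source may report more compounds than this note shows. Statements on the series, on what has been measured and on what is new or still open speak of the compounds shown alone.

Values so far in a functional assay on HL-60 cells (Homo sapiens) for antiproliferative activity, read by MTT assay, with a stated time of 72 h (on this read-out higher numbers stand for weaker inhibition and lower numbers for stronger inhibition), are:
- compound 1 `NC1=NC2(CCOCC2)N(OCCCOc2ccccc2)C(N)=N1` gives 2460 nM
- compound 2 `NC1=NC2(CCOCC2)N(OCCCOc2cccc(Cl)c2Cl)C(N)=N1` gives 440 nM
- compound 3 `Cc1cc(C)cc(OCCCON2C(N)=NC(N)=NC23CCOCC3)c1` gives 720 nM

Compound 3 is level with compound 2 within the scatter and clearly under compound 1 on these numbers. The next entry is compound 4 `NC1=NC2(CCOCC2)N(OCCCOc2cc(Cl)c(Cl)cc2Cl)C(N)=N1`, which carries 2,4,5-trichlorophenyl in place of 3,5-dimethylphenyl on an oxygen on a saturated carbon.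

Going by the values given here, three measured steps bear on this change. The step to 2,3-dichlorophenyl (a 5.6-fold lower number from compound 1 to compound 2 (0.75 log units; beyond the scatter)) and the step to 3,5-dimethylphenyl (a 3.4-fold lower number from compound 1 to compound 3 (0.53 log units; beyond the scatter)) are both modest and beyond the scatter. Exchanging one of these groups for the other (a 1.6-fold higher number from compound 2 to compound 3 (0.21 log units; within the scatter)) stays within it. Among the compounds with values here, both substituted phenyl groups thus gave lower numbers than phenyl, and no measured compound goes against that. Within the data shown here, the series holds no other trichlorophenyl compound, so the effect of a third chlorine is unknown, and the nearest guide is compound 2 (440 nM).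

The estimate is a 1.8-fold lower number from compound 3 to compound 4 (0.26 log units; within the scatter) and so no step beyond the scatter is expected. In this assay compound 4 is estimated at 400 nM (expected range 150 nM to 1100 nM).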

Compound 4, half-maximal inhibitory concentration: 2360 nM
The estimate for compound 4 lay 5.9-fold (0.77 log units) below the measured number; the whole stated range lies below it.
By their numbers in this assay, from the lowest: compounds 2 and 3 (each within the scatter of the next); then compounds 4 and 1 (each within the scatter of the next).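

In this assay, a chlorinated phenyl group at this place does not by itself hold the lower number: a 5.4-fold higher number from compound 2 to compound 4 (0.73 log units; beyond the scatter) for the exchange of 2,3-dichlorophenyl for 2,4,5-trichlorophenyl, and the exchange of 3,5-dimethylphenyl for the same group gives a 3.3-fold higher number from compound 3 to compound 4 (0.52 log units; beyond the scatter). With a 1.0-fold lower number from compound 1 to compound 4 (0.02 log units; within the scatter), 2,4,5-trichlorophenyl stands level with unsubstituted phenyl, so compound 4 goes against the earlier reading that substituted phenyl groups give lower numbers than phenyl, and that reading now holds only for compound 2 and compound 3. No measurement at hand accounts for this reversal.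

Compound 2 and compound 4 differ in both the count and the placing of their chlorines, which leaves open whether the third chlorine or the changed pattern goes with the higher number. Going by these compounds, how a monochlorophenyl, a methoxyphenyl or a pyridyl ring would read at this place remains open, as does whether the same order of aromatic groups would hold on a longer chain.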